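The compounds below may be only part of what the source reports. "The series", "measured", "known", "first", "only" and "open" are said of these compounds alone.

Compound 1: `CCN(CC)CCCn1c(=O)c(=Cc2ccc(F)cc2F)s/c1=C1\C(=O)Nc2ccc(Cl)cc21`, > 200000 nM. Compound 2: `CCN(CC)CCCn1c(=O)c(=Cc2ccc(O)cc2)s/c1=C1\C(=O)Nc2ccc(C)cc21`, 770 nM.

In a functional assay on HT-29 cells (Homo sapiens) for inhibition, read by MTT assay, with a stated time of 72 h (on this read-out higher numbers stand for weaker inhibition and lower numbers for stronger inhibition), compound 1 gives only a limit of the assay, > 200000 nM, so its standing is known just as sitting at the limit of > 200000 nM in this assay, at which 1 of the 2 values shown sits. Compound 2 gives 770 nM in this assay. These two compounds differ in more than one place, so their values show only that one sits at the limit while the other is a number.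

Compound 3, `CCN(CC)CCCn1c(=O)c(=Cc2ccc(F)cc2F)s/c1=C1\C(=O)Nc2ccccc21`, differs from compound 1 in a single place: hydrogen in place of chloro on an aromatic carbon. No step of this kind has been measured among these compounds. With compound 1 resting at a limit, the size of the step from it cannot be read from a measured value; a move toward stronger inhibition in this assay is possible but uncertain. Compound 3 is expected to give about 20000 nM in this assay, within 2000 nM to 200000 nM. This corresponds to an expected step of an at least 10-fold lower number from compound 1 to compound 3 (1.00 log units; beyond the scatter).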

Compound 3, half-maximal inhibitory concentration: > 200000 nM
Compound 3 was reported as a limit; the forecaster's own chance of this, stated with the estimate: 35%; at least 10-fold (1.00 log units) between middle value and limit.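

Compound 1 and compound 3 each give only a limit of the assay, not a number, so no step between them can be read: the limit of > 200000 nM in this assay, at which 2 of the 3 values shown sit.

The compounds shown leave open whether hydrogen in place of chloro changes inhibition at all in this assay.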